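Swapping a Methylphenyl Group for an Iodophenyl Group

The compounds below may be only part of what the source reports. "The series", "measured", "known", "first", "only" and "open" are said of these compounds alone.

Values in a functional assay on HeLa cells (Homo sapiens) for antiproliferative activity, read by MTT assay, with a stated time of 48 h; on this read-out higher numbers stand for weaker inhibition and lower numbers for stronger inhibition
- Compound 1 `Cc1ccc(-c2nn(-c3ccccc3)cc2C(Nc2nc3cc(C)c(C)cc3s2)c2c(O)ccc3ccccc23)cc1` gives 17800 nM
- Compound 2 `Oc1ccc2ccccc2c1C(Nc1nc2ccccc2s1)c1cn(-c2ccccc2)nc1-c1ccccc1` gives 17300 nM
- Compound 3 `Cc1cccc(-c2nn(-c3ccccc3)cc2C(Nc2nc3ccccc3s2)c2c(O)ccc3ccccc23)c1` gives 7020 nM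

Compound 3 has the lowest of these three numbers, which makes it the strongest inhibitor so far. Compound 4 `Oc1ccc2ccccc2c1C(Nc1nc2ccccc2s1)c1cn(-c2ccccc2)nc1-c1ccc(I)cc1` has 4-iodophenyl in place of 3-methylphenyl on an aromatic carbon. The closest measured evidence is a 2.5-fold lower number from compound 2 to compound 3 (0.39 log units; beyond the scatter), a modest change that came with adding a methyl. Compound 4 lacks that methyl, so some of the gain may be lost. Yet compound 1, which carries methyl groups of its own, gives 17800 nM, so methyl does not always help. Among the measured compounds shown here, no iodine compound has been measured, which leaves the outcome uncertain. A modest rise in this assay is expected, and the expected size is a 1.6-fold higher number from compound 3 to compound 4 (0.20 log units; within the scatter). For compound 4 the estimated value is 11000 nM, within an expected range of 4000 nM to 30000 nM.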

Compound 4, half-maximal inhibitory concentration: 6590 nM
Compound 4: middle estimate off by 1.7-fold (0.22 log units), on the high side, within the range that was stated.
By their numbers in this assay, from the lowest: compounds 4 and 3 (each within the scatter of the next); then compounds 2 and 1 (each within the scatter of the next).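

In this assay, iodo in place of hydrogen on the phenyl group gives a 2.6-fold lower number from compound 2 to compound 4 (0.42 log units; beyond the scatter), so a gain at this position is not tied to methyl alone. Exchanging 3-methylphenyl for 4-iodophenyl gives a 1.1-fold lower number from compound 3 to compound 4 (0.03 log units; within the scatter), which leaves the two groups indistinguishable in this assay. No measurement at hand explains why either group goes with a lower number.

Still open, on these data alone, is whether 3-iodophenyl would match 4-iodophenyl. Also open, as far as these compounds go, is whether a phenyl group carrying an amine or a carboxylic acid would keep the gain.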